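The compounds below may be only part of what the source reports. "The series", "measured", "known", "first", "only" and "open" are said of these compounds alone.

Measured compounds:
compound 1, `COc1cc(-n2ncnc2-c2ccc(F)cc2)cc(OC)c1OC`: > 10000 nM
compound 2, `COc1cc(-c2ncnn2-c2ccc(Cl)cc2Cl)cc(OC)c1OC`: > 10000 nM

In a functional assay on HL-60 cells (Homo sapiens) for antiproliferative activity, read by MTT assay, with a stated time of 72 h (on this read-out higher numbers stand for weaker inhibition and lower numbers for stronger inhibition), compound 1 gives > 10000 nM, which is a limit of the assay rather than a number. Compound 2 likewise reaches only a limit in this assay, at > 10000 nM. Among the measured compounds shown here, the two compounds differ in more than one place, so no single step between them can be read; what their two values show is that both sit at the limit of > 10000 nM in this assay, at which 2 of the 2 values shown sit. Compound 1 therefore stands at the weak end of everything shown, and no measured value gives a scale for it.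

Compound 3, `COc1cc(-n2ncnc2-c2ccc(SC)cc2)cc(OC)c1OC`, is the next compound to be measured in this assay. It differs from compound 1 by methylsulfanyl in place of fluoro on an aromatic carbon. No measured step is available for this change, and the two values shown give no reason to expect compound 3 to move clearly away from the limit; the most likely outcome is again a limit, with any real number expected only modestly beyond the scatter, as in the step that the limit leaves unreadable from compound 1 to compound 3. Compound 3 is thus estimated at 15000 nM, between 5000 nM and 50000 nM.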

Compound 3, half-maximal inhibitory concentration: 500 nM
Compound 3: middle estimate off by 30-fold (1.48 log units), on the high side; the measured number lies below the stated range.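

Compound 3 shows that this position, on an aromatic carbon of a six-membered aromatic ring of carbon only and para to a large group, can separate a measurable compound from an unmeasurable one: in this assay, methylsulfanyl in place of fluoro gives an at least 20-fold lower number from compound 1 to compound 3 (1.30 log units; beyond the scatter). Compound 1 starts from a limit. Going by these compounds, this step therefore fixes only a minimum size, and the full size of the change remains unknown. Compound 3 is also the only compound shown that gives a number, so the core of compound 1 can no longer be read as inactive whatever group it carries, while the remaining compounds stay at a limit: the limit of > 10000 nM in this assay, at which 2 of the 3 values shown sit.

On these data alone, what remains open is whether the gain belongs to the sulfur atom or to the methyl on it, and whether other groups at this position, such as methoxy, ethylsulfanyl, methylsulfonyl or dimethylamino, would match the value of compound 3. Among the compounds shown here, it is also open whether methylsulfanyl would have a similar effect on the core of compound 2, which differs from compound 1 in more than one place and so gives no step that can be read.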